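The compounds below may be only part of what the source reports. "The series", "measured", "known", "first", "only" and "open" are said of these compounds alone.

Three measured compounds share one core and differ at two places. Compound 1, `Cc1ccc2c(Cc3nn4c(C=O)c(-c5ccc(Cl)cc5)nc4s3)coc2c1`, carries a formyl group and a 4-chlorophenyl group; in a functional assay on the whole organism (strain Wistar albino) for inhibition, with Rattus norvegicus as the target, read by paw edema, with a stated time of 0.5 h, at a dose of 100 mg/kg by the oral route (a higher number here means more inhibition at the dose given (going by the name of the read-out), a lower number less inhibition), compound 1 gives 3.6%. Compound 2, `Cc1ccc2c(Cc3nn4c(C=O)c(-c5ccc(Br)cc5)nc4s3)coc2c1`, differs from it by bromo in place of chloro on an aromatic carbon; in this assay compound 2 gives 1.15%, the step being a number 2.5 percentage points lower from compound 1 to compound 2 (within the scatter). Compound 3, `Cc1ccc2c(Cc3nn4c(CO)c(-c5ccc(Cl)cc5)nc4s3)coc2c1`, differs from compound 1 by hydroxymethyl in place of formyl on an aromatic carbon; in this assay compound 3 gives 9.61%, the step being a number 6 percentage points higher from compound 1 to compound 3 (within the scatter). Compound 4, `Cc1ccc2c(Cc3nn4c(CO)c(-c5ccc(Br)cc5)nc4s3)coc2c1`, has not yet been measured in this assay. It differs from compound 3 by bromo in place of chloro on an aromatic carbon, which is the same change that leads from compound 1 to compound 2, the surroundings of the place being described in identical words in both cases. For compound 4 the expected step is a number 2.6 percentage points lower from compound 3 to compound 4 (within the scatter). Going by the values given here, this expectation rests on the step of a number 2.5 percentage points lower from compound 1 to compound 2 (within the scatter), the only occurrence of the change measured so far, and on the fact that no other pair here informs it. Compound 4 is therefore estimated at 7%, with a range from 0% to 17%.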

Compound 4, a percentage reported as inhibition, in the whole organism at one dose (the size of the read-out at that dose, not a potency): 2.38%
Compound 4: middle estimate off by 4.6 percentage points, on the high side; the measured number falls inside the stated range.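

In this assay, the step for bromo in place of chloro on the hydroxymethyl compounds is a number 7.2 percentage points lower from compound 3 to compound 4 (within the scatter), and it agrees with the earlier step for the same change: the same change on two cores in this assay, a number 2.5 percentage points lower (within the scatter) from compound 1 to compound 2 and a number 7.2 percentage points lower (within the scatter) from compound 3 to compound 4, 4.8 percentage points apart, within the scatter of two such steps. The step for hydroxymethyl in place of formyl on the bromo compounds is a number 1.2 percentage points higher from compound 2 to compound 4 (within the scatter), and it likewise agrees with its earlier counterpart: the same change on two cores in this assay, a number 6 percentage points higher (within the scatter) from compound 1 to compound 3 and a number 1.2 percentage points higher (within the scatter) from compound 2 to compound 4, 4.8 percentage points apart, within the scatter of two such steps. Across these four compounds, neither change reads differently from one core to the other, but because every step lies within the scatter, this does not show that either change has a real effect that carries over, and each comparison rests on just two steps.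

The compounds shown leave open how an amine or a methoxy group in the place of the halogen, or a carboxylic acid in the place of the formyl group, would read in this assay. They also leave open how any of these compounds would read at another dose or another time.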